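The compounds below may be only part of what the source reports. "The series", "measured", "known", "first", "only" and "open" are said of these compounds alone.

Within the data shown here, compound 1 `COC(=O)c1cccc(NC(=O)c2cc3cc([N+](=O)[O-])ccc3o2)c1` is the first of three measured compounds in this set. In a physicochemical assay for solubility (a higher number here means a more soluble compound, a lower number a less soluble compound), compound 1 gives 25 ug/mL. Compound 3 `NC(=O)c1cccc(NC(=O)c2cc3cc([N+](=O)[O-])ccc3o2)c1` differs from compound 1 in one place only, by amino in place of methoxy on a carbonyl carbon and in this assay compound 3 gives 20 ug/mL. That single change made the step of a 1.3-fold lower number from compound 1 to compound 3 (0.10 log units; within the scatter), so the two numbers show no separation that the measurement can support.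

Compound 2 `COC(=O)c1ccc(NC(=O)c2ccc3ccccc3c2)cc1` sits on a different core; how its core differs from that of compound 1 is not broken down here. In this assay compound 2 gives 25 ug/mL, level with compound 1 at the digits recorded, and its gap to compound 3 also lies within the scatter.

Compound 4 `NC(=O)c1ccc(NC(=O)c2ccc3ccccc3c2)cc1` has not yet been measured in this assay. It differs from compound 2 by amino in place of methoxy on a carbonyl carbon and the place of this change reads word for word as it does between compound 1 and compound 3, so it is the same change made on the core of compound 2. Among the measured compounds shown here, the only precedent for it is the pair of compound 1 and compound 3, where it gave a 1.3-fold lower number from compound 1 to compound 3 (0.10 log units; within the scatter). On that precedent alone the step from compound 2 to compound 4 is expected to be small, about a 1.3-fold lower number from compound 2 to compound 4 (0.10 log units; within the scatter), because a 1.3-fold lower number from compound 1 to compound 3 (0.10 log units; within the scatter) left the number essentially unchanged. Compound 4 is therefore estimated to give 20 ug/mL in this assay, with a likely range from 8 ug/mL to 50 ug/mL.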

Compound 4, solubility: < 5 ug/mL
Compound 4: a limit, no number; the forecaster's own chance of this, stated with the estimate: 5%; middle value at least 4.0-fold (0.60 log units) away from the limit.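

Compound 4 gives < 5 ug/mL in this assay, which is a limit of the assay and not a number, so the step from it is a bound on the real size: the limit of < 5 ug/mL in this assay, at which 1 of the 4 values shown sits.

The change from methoxycarbonyl to carbamoyl did not carry over from one core to the other at the same size, giving a 1.3-fold lower number from compound 1 to compound 3 (0.10 log units; within the scatter) on the core of compound 1 and an at least 5.0-fold lower number from compound 2 to compound 4 (0.69 log units; beyond the scatter) on the core of compound 2, the first within the scatter and the second beyond it. Among these compounds, with only one pair on each core and cores that differ in more than one place, the result does not show which part of the cores separates the two steps, how large the second step really is, or whether the same contrast would hold on any further core.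

The compounds shown leave open how the core of compound 2 responds to other groups on the carbonyl carbon, such as a methylamino or dimethylamino group in place of amino, or the hydroxyl of a carboxylic acid. They also leave open whether the nitro group on the core of compound 1 has any part in the contrast, as no pair shown isolates it.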